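The compounds below may be only part of what the source reports. "The series", "measured", "known", "first", "only" and "open" are said of these compounds alone.

Of the compounds shown here, two built on a shared core have so far been measured in a functional assay on UACC-62 cells (Homo sapiens) for inhibition, read by sulforhodamine B assay, with a stated time of 48 h; a higher number here means a weaker inhibitor of growth, a lower number a stronger inhibitor of growth. Compound 1 `O=C(Nc1cccc(-n2cc(-c3ccncc3)c(-c3ccc(Cl)c(O)c3)n2)c1)Nc1cccc(C(F)(F)F)c1` gives 1650 nM in this assay. Compound 2 `COc1cc(-c2nn(-c3cccc(NC(=O)Nc4cc(C(F)(F)F)cc(C(F)(F)F)c4)c3)cc2-c2ccncc2)ccc1Cl` gives 661 nM in this assay, the lowest of the two numbers, and its gap to compound 1 lies beyond the usual scatter of repeated measurements. Compound 3 `O=C(Nc1cccc(-n2cc(-c3ccncc3)c(-c3ccc(Cl)c(O)c3)n2)c1)Nc1cc(C(F)(F)F)cc(C(F)(F)F)c1` has not yet been measured. It differs from compound 2 in a single place: hydrogen in place of methyl on an oxygen on an aromatic ring, in words, hydrogen in place of methyl on an oxygen on an aromatic ring. For the measured compounds named here, no measured pair shows this change on its own, so its size and direction in this assay are not known from these data; compound 1 also carries the hydroxy, but it differs from compound 3 in a second place too and cannot settle the question. A step of modest size from compound 2 to compound 3 is expected, a 1.3-fold higher number from compound 2 to compound 3 (0.11 log units; within the scatter), with no firm direction. Compound 3 is estimated at 850 nM, within a range of 250 nM to 2800 nM.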

Compound 3, concentration for 50% growth inhibition: 749 nM
Compound 3: middle estimate off by 1.1-fold (0.05 log units), on the high side, within the range that was stated.
By their numbers in this assay, from the lowest: compounds 2 and 3 (each within the scatter of the next); then compound 1.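

In this assay, replacing methoxy with hydroxy on the 4-chloro-3-methoxyphenyl ring gives a 1.1-fold higher number from compound 2 to compound 3 (0.05 log units; within the scatter) and so leaves growth inhibition indistinguishable, which means that on this background the methyl on that oxygen can go without a measurable change. With the hydroxy held fixed, the added trifluoromethyl gives a 2.2-fold lower number from compound 1 to compound 3 (0.34 log units; beyond the scatter) and is the only single change shown here that clears the scatter, though only modestly. Nothing measured here explains either step.

From the compounds shown here alone, whether methoxy and hydroxy also match on the background of compound 1, which carries one trifluoromethyl fewer, stays open. So does what an ethoxy group, a longer chain or an amine would do at this place on the ring.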